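This account rests on a few compounds, and the source may have more. Where it says the series, first, only, none or still open, it means among the compounds named here.

Measured so far in a functional assay on MGC-803 cells (Homo sapiens) for antiproliferative activity, read by MTT assay, with a stated time of 48 h; a higher number here means a weaker inhibitor, a lower number a stronger inhibitor
- compound 1 `COc1ccc(CN(C(=O)CSc2nc3ccccc3s2)c2cc(OC)c(OC)c(OC)c2)cc1C` gives 6360 nM
- compound 2 `COc1cc(N(Cc2ccc(C)cc2)C(=O)CSc2nc3ccccc3s2)cc(OC)c1OC` gives 54200 nM
- compound 3 `COc1ccc(CN(C(=O)CSc2nc3ccccc3s2)c2cc(OC)c(OC)c(OC)c2)cc1OC` gives 34100 nM

Compound 3 cannot be told apart from compound 2, since a 1.6-fold lower number from compound 2 to compound 3 (0.20 log units; within the scatter). Only compound 1 stands clearly apart from it, as a 5.4-fold higher number from compound 1 to compound 3 (0.73 log units; beyond the scatter) shows.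

Compound 4 `COc1cc(N(Cc2ccc(Cl)cc2)C(=O)CSc2nc3ccccc3s2)cc(OC)c1OC` keeps the rest of compound 3 and alters one group, with 4-chlorophenyl in place of 3,4-dimethoxyphenyl on a saturated chain carbon bound to an amide-type nitrogen. The count of that change is 4-chlorophenyl in place of 3,4-dimethoxyphenyl on a saturated chain carbon bound to an amide-type nitrogen.

All three measured steps change this same group, so all three bear on the question. Two are modest: an 8.5-fold higher number from compound 1 to compound 2 (0.93 log units; beyond the scatter) and a 5.4-fold higher number from compound 1 to compound 3 (0.73 log units; beyond the scatter). Both start from the 4-methoxy-3-methylphenyl group of compound 1. The third, a 1.6-fold lower number from compound 2 to compound 3 (0.20 log units; within the scatter), lies within the scatter. Within the data shown here, with only one group giving a clearly lower number, there is no firm reason to expect 4-chlorophenyl to behave like it, so the expectation in this assay is for no step beyond the scatter. A modest step remains possible, so the range stays wide.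

For compound 4 the expected value is 30000 nM, with an estimated range from 8000 nM to 80000 nM. The step this estimate means is a 1.1-fold lower number from compound 3 to compound 4 (0.06 log units; within the scatter).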

Compound 4, half-maximal inhibitory concentration: > 80000 nM
Compound 4: a limit, no number (the forecaster's own chance of this, stated with the estimate: 10%); middle value at least 2.6-fold (0.42 log units) away from the limit.
By their numbers in this assay, from the lowest: compound 1; then compounds 3 and 2 (each within the scatter of the next). At a limit, above all of these: compound 4.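

In this assay, compound 4 is a limit and not a number: the limit of > 80000 nM in this assay, at which 1 of the 4 values shown sits.

Even so, this limit gives the first clear move away from the 3,4-dimethoxyphenyl group, with an at least 2.3-fold higher number from compound 3 to compound 4 (0.37 log units; beyond the scatter), whereas the earlier 4-methylphenyl compound could not be told apart from compound 3. It also widens the gap to the best group at this place, with an at least 12-fold higher number from compound 1 to compound 4 (1.09 log units; beyond the scatter), so compound 1 stays the strongest of the four, and this saturated chain carbon bound to an amide-type nitrogen now has three groups that all fall clearly short of 4-methoxy-3-methylphenyl. Chloro in place of methyl on an aromatic carbon cannot be sized, because only a floor is available, with an at least 1.4-fold higher number from compound 2 to compound 4 (0.16 log units; that floor lies within the scatter), so compounds 2 and 4 cannot be put in order.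

The compounds shown leave open which part of the 4-methoxy-3-methylphenyl group carries its advantage, since neither 4-methoxyphenyl nor 3-methylphenyl appears here on its own. They also leave open whether a different group at this place, such as 4-fluorophenyl, 4-aminophenyl or a pyridine ring, could match or pass compound 1.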